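Methyl in place of hydrogen on the aryl ring

The compounds below may be only part of what the source reports. "The series", "measured", "known", "first", "only" and "open" are said of these compounds alone.

Compound 1, `COCC(C(=O)N1CCN(c2cccc(C(F)(F)F)c2)CC1)N1C(=O)CCC1=O`, gives 50% in a functional assay on the whole organism (strain Swiss) with Mus musculus as the target, in the maximal electroshock model, with a stated time of 0.5 h, at a dose of 300 mg/kg by the intraperitoneal route; on this read-out lower numbers stand for a weaker effect and higher numbers for a stronger effect at the one dose given.
Compound 2, `CC(C(=O)N1CCN(c2ccccc2)CC1)N1C(=O)CCC1=O`, gives 50% in this assay.
Compound 3, `CCC(C(=O)N1CCN(c2cccc(OC)c2)CC1)N1C(=O)CCC1=O`, gives 0% in this assay.

Compound 2 stands level with compound 1 at the digits shown, and together the two share the highest of the three numbers; the gap between them lies within the scatter. Compound 3 stands furthest from compound 2, its number being lower by an amount beyond the scatter. Compound 3, though, differs from compound 2 in more than one place, so nothing about a single change can be read from that pair.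

The unmeasured compound 4, `Cc1cccc(N2CCN(C(=O)C(C)N3C(=O)CCC3=O)CC2)c1`, differs from compound 2 by one change: methyl in place of hydrogen on an aromatic carbon. Going by the values given here, no pair of measured compounds separated by a single change exists here, so the step has no direct precedent. Compound 1, which carries a trifluoromethyl group at the place where compound 4 carries its methyl, sits within the scatter of compound 2, which suggests that a group at that place need not lower the number. For compound 4 the step of a number 10 percentage points lower from compound 2 to compound 4 (within the scatter) is expected to fall within the scatter, or at most slightly lower. Compound 4 is therefore estimated at 40%, with a range from 0% to 75%.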

Compound 4, a percentage reported as activity, at one dose (the size of the read-out at that dose, not a potency): 50%
Compound 4: middle estimate off by 10 percentage points, on the low side; low and high end bracket the measured number.
By their numbers in this assay, from the lowest: compound 3; then compounds 1, 2 and 4 (each within the scatter of the next).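

Going by these compounds alone, the step from phenyl to 3-methylphenyl gives no change at the digits printed from compound 2 to compound 4 (within the scatter) in this assay, and it is the first comparison in this set in which only one place differs. It shows that, at the one dose given, methyl on this aromatic carbon, meta to a large group, leaves the read-out where it stood with hydrogen, so this change on its own gives no sign of either a loss or a gain of effect; since the read-out gives the size of the effect at that dose and not a potency, a shift at other doses cannot be excluded. Nothing measured alongside these compounds bears on why the number stays the same.

The compounds shown leave open whether a group other than methyl at this place, such as an amine, a carboxylic acid or a longer chain like propyl, would also leave the number unchanged when it is the only difference from compound 2. They also leave open whether methyl on another carbon of the same ring would behave as it does here.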